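Compound 4 against the limit of the assay

The source may report more compounds than this note shows. Statements on the series, on what has been measured and on what is new or still open speak of the compounds shown alone.

Compound 1 `COc1ccc(/C=C\c2cc(OC)c(OC)c(OC)c2)cc1OCc1ccc(CN[C@H](C(=O)O)[C@H](C)O)cc1`: > 10000 nM, a limit
Compound 2 `COc1ccc(/C=C\c2cc(OC)c(OC)c(OC)c2)cc1OCc1ccc(CN2CC[C@H](C(=O)O)C2)cc1`: > 10000 nM, a limit
Compound 3 `COc1ccc(/C=C\c2cc(OC)c(OC)c(OC)c2)cc1OCc1ccc(CN2CC[C@H](O)C2)cc1`: 7200 nM

In a functional assay on MC-38 cells (Mus musculus) for antiproliferative activity, read by CCK-8 assay, with a stated time of 48 h (on this read-out higher numbers stand for weaker inhibition and lower numbers for stronger inhibition), compound 1 stands at a limit, > 10000 nM, and not at a number. Its position is the limit of > 10000 nM in this assay, at which 2 of the 3 values shown sit. Compound 4 `COc1ccc(/C=C\c2cc(OC)c(OC)c(OC)c2)cc1OCc1ccc(CN2CC[C@@H](C(=O)O)C2)cc1` departs from it by one change: 3-carboxypyrrolidin-1-yl in place of (1-carboxy-2-hydroxypropyl)amino on a saturated chain carbon bound to an aromatic carbon. For the measured compounds named here, the one measured step with this same change in words is a step that the two limits leave unreadable from compound 1 to compound 2. Compound 2 carries the same 3-carboxypyrrolidin-1-yl group, with the opposite defined stereocentre to compound 4. Compound 2 too sits at a limit, > 10000 nM. The other two steps, an at least 1.3-fold lower number from compound 1 to compound 3 (0.14 log units; that floor lies within the scatter) and an at least 1.3-fold lower number from compound 2 to compound 3 (0.14 log units; that floor lies within the scatter), lead to the 3-hydroxypyrrolidin-1-yl group instead and bear only loosely on the change. No step beyond the scatter is therefore expected in this assay, and a second report as a limit is likely. The expected change is a step that the limit leaves unreadable from compound 1 to compound 4. Compound 4 is estimated at 12000 nM, with an expected range of 6000 nM to 25000 nM.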

Compound 4, half-maximal inhibitory concentration: 6300 nM
The estimate for compound 4 lay 1.9-fold (0.28 log units) above the measured number, and the stated range covers the measured number.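

Compound 4 gives the 3-carboxypyrrolidin-1-yl group a number in this assay rather than a limit, and the steps to it, an at least 1.5-fold lower number from compound 1 to compound 4 (0.20 log units; that floor lies within the scatter) and an at least 1.5-fold lower number from compound 2 to compound 4 (0.20 log units; that floor lies within the scatter) are floors, both set by one boundary: the limit of > 10000 nM in this assay, at which 2 of the 4 values shown sit.
For the compounds shown here, the second floor is the first step here that concerns configuration alone, so anything separating that pair comes down to a single difference: the fact that compounds 2 and 4 differ only in the configuration as drawn.
On the saturated ring, the comparison with the hydroxy compound gives a 1.1-fold lower number from compound 3 to compound 4 (0.06 log units; within the scatter) and so does not tell the 3-carboxypyrrolidin-1-yl and 3-hydroxypyrrolidin-1-yl groups apart.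

As far as these compounds go, the true size of the steps from compound 1 and compound 2 stays open, and the floors do not show that the configuration matters. The compounds shown also leave open how a 3-aminopyrrolidin-1-yl group or a piperidine ring bearing a carboxylic acid would read at this place.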